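This account rests on a few compounds, and the source may have more. Where it says the series, first, only, none or still open, it means among the compounds named here.

The measured compounds:
Compound 1 `Cc1cc(C(=O)c2ccccc2)ccc1OCC(=O)Nc1nc(-c2ccccc2)cs1` gives 22300 nM in a functional assay on DLA cells (Mus musculus) for cytotoxicity, read by MTT assay, with a stated time of 48 h; on this read-out higher numbers stand for weaker inhibition and lower numbers for stronger inhibition.
Compound 2 `COc1ccc(-c2csc(NC(=O)COc3ccc(C(=O)c4ccccc4)cc3C)n2)cc1` gives 25700 nM in this assay.
Compound 3 `COc1ccc(-c2csc(NC(=O)COc3c(C)cc(C(=O)c4ccccc4)cc3C)n2)cc1` gives 39400 nM in this assay.

Among these three numbers compound 2 stands second highest; compound 1 is nearest to it and compound 3 furthest, and both gaps are within the scatter, so no order among the three can be read from them. Compound 4 `COc1ccc(-c2csc(NC(=O)COc3ccc(C(=O)c4cccc(Br)c4)cc3C)n2)cc1` has not yet been tested. It differs from compound 2 in one place: bromo in place of hydrogen on an aromatic carbon. For the measured compounds named here, two measured steps bear on this change, since each of them also adds a single small group on an aromatic carbon of the shared core: a 1.2-fold higher number from compound 1 to compound 2 (0.06 log units; within the scatter) and a 1.5-fold higher number from compound 2 to compound 3 (0.19 log units; within the scatter). Neither moved the number beyond the scatter. On that basis the change from compound 2 to compound 4 is expected to give no step beyond the scatter, which means an expected 1.1-fold higher number from compound 2 to compound 4 (0.02 log units; within the scatter). Compound 4 is therefore estimated at 27000 nM in this assay, with a range expected from 12000 nM to 60000 nM.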

Compound 4, half-maximal inhibitory concentration: 36600 nM
For compound 4 the middle estimate is 1.4-fold (0.13 log units) below the measured one; the measured number falls inside the stated range.
By their numbers in this assay, from the lowest: compounds 1, 2, 4 and 3 (each within the scatter of the next).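

For the compounds shown here, on the benzoyl end of the shared core, where none of the earlier steps had made a change, bromo in place of hydrogen gives a 1.4-fold higher number from compound 2 to compound 4 (0.15 log units; within the scatter) in this assay. A bromine atom on this ring, meta to a large group, therefore leaves the number within the scatter of compound 2, and the change joins the methoxy and methyl steps, which also stayed within it at their own places on the shared core. Nothing measured here gives a reason for the size of this step.

From the compounds shown here alone, whether a different group at this place, such as an amine, a carboxylic acid or a longer chain, would move the number beyond the scatter stays open. Also open, going by these compounds, is whether bromo would behave the same way on the core of compound 1 or of compound 3.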